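The source may report more compounds than this note shows. Statements on the series, on what has been measured and on what is new or still open speak of the compounds shown alone.

Working notes on the series. All three measured compounds share one core and were tested in a functional assay on T47D cells (Homo sapiens) for inhibition; a lower number here means a stronger inhibitor, a higher number a weaker inhibitor. Compound 1 `Oc1cccc(-c2cc(-c3ccccc3OC(F)(F)F)cc(-c3ccccc3O)n2)c1` gives 2680 nM. Compound 3 `Oc1ccc(-c2cc(-c3ccccc3OC(F)(F)F)cc(-c3ccccc3O)n2)cc1` gives 2050 nM. The change between them is 4-hydroxyphenyl in place of 3-hydroxyphenyl on an aromatic carbon, and it moved the number by a 1.3-fold lower number from compound 1 to compound 3 (0.12 log units; within the scatter), so this step is flat. Compound 2 `Oc1cccc(-c2cc(-c3ccc(OC(F)(F)F)cc3)cc(-c3ccccc3O)n2)c1` gives 7710 nM, the highest number of the three; how the core of compound 2 differs from the core of compound 1 is not broken down here. Compound 4 `Oc1ccc(-c2cc(-c3ccc(OC(F)(F)F)cc3)cc(-c3ccccc3O)n2)cc1` has not yet been measured. It differs from compound 2 by 4-hydroxyphenyl in place of 3-hydroxyphenyl on an aromatic carbon, the same change as that from compound 1 to compound 3, made at the same place. The change has been seen only once before, and that instance stayed within the scatter. The expected step is therefore small, estimated at a 1.3-fold lower number from compound 2 to compound 4 (0.11 log units; within the scatter), resting on the earlier step of a 1.3-fold lower number from compound 1 to compound 3 (0.12 log units; within the scatter). Because compound 2 gives 7710 nM, compound 4 is expected near that number. Compound 4 is estimated at 6000 nM, with a likely range from 3000 nM to 12000 nM.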

Compound 4, half-maximal inhibitory concentration: > 50000 nM
Compound 4 gave a limit, no number; the forecaster's own chance of this, stated with the estimate: 5%; middle value at least 8.3-fold (0.92 log units) away from the limit.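

In this assay, compound 4 gives > 50000 nM, which is a limit of the assay and not a number. Putting 4-hydroxyphenyl in place of 3-hydroxyphenyl gives an at least 6.4-fold higher number from compound 2 to compound 4 (0.81 log units; beyond the scatter), so a change that was flat on the core of compound 1 does not carry over unchanged to the core of compound 2: the same change on two cores in this assay, a 1.3-fold lower number (0.12 log units; within the scatter) from compound 1 to compound 3 and an at least 6.4-fold higher number (0.81 log units; beyond the scatter) from compound 2 to compound 4, at least 8.4-fold (0.92 log units) apart, beyond the scatter of two such steps This shows that the earlier step cannot be transferred between these two cores, but it gives neither the full size of the new step nor a rule for the series, since only one pair of steps is available and one of them ends at a limit: the limit of > 50000 nM in this assay, at which 1 of the 4 values shown sits.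

The compounds shown leave open which difference between the two cores goes with the different outcome. They also leave open how the same change behaves when a methoxy group or a chlorine stands in place of the trifluoromethoxy group, or when an amine replaces the hydroxyl of the hydroxyphenyl ring.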